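Swapping the Dienyl Ether for a Chlorophenyl Carbamate

The source may report more compounds than this note shows. Statements on the series, on what has been measured and on what is new or still open speak of the compounds shown alone.

Compound 1 `CC(C)=CCC/C(C)=C/COc1cc(=O)n(CCCO)c2c1CC(CC=C(C)C)C(C)(C)C2` gives 10.6% in a functional assay on PANC-1 cells (Homo sapiens) for inhibition, read by MTT assay, with a stated time of 24 h, tested at 10 uM; a higher number here means more inhibition at the concentration tested (going by the name of the read-out), a lower number less inhibition.
Compound 2 `CC(C)=CCC1Cc2c(OC(=O)Nc3ccc(F)cc3F)cc(=O)n(CCCO)c2CC1(C)C` gives 69.7% in this assay.
Compound 3 `CC(C)=CCC/C(C)=C/COc1cc(=O)n(CCCO)c2c1CC(C/C=C(\C)CCC=C(C)C)C(C)(C)C2` gives 15.8% in this assay.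

Among these three numbers compound 3 stands second highest. Its nearest neighbour is compound 1: the step of a number 5.2 percentage points higher from compound 1 to compound 3 (within the scatter) lies within the scatter, so the two cannot be told apart, and adding a 3-methylbut-2-en-1-yl group to the saturated chain carbon left the read-out essentially unchanged. Compound 2 stands far above both, as the step of a number 59.1 percentage points higher from compound 1 to compound 2 (beyond the scatter) shows.

Compound 4 `CC(C)=CCC/C(C)=C/CC1Cc2c(OC(=O)Nc3ccc(Cl)cc3)cc(=O)n(CCCO)c2CC1(C)C` is the next compound to be measured. It differs from compound 3 by (4-chlorophenyl)carbamoyl in place of 3,7-dimethylocta-2,6-dien-1-yl on an oxygen on an aromatic ring. This is the same kind of exchange that separates compound 1 from compound 2, where a (2,4-difluorophenyl)carbamoyl group took the place of the same 3,7-dimethylocta-2,6-dien-1-yl chain on the ring oxygen and the number rose sharply, beyond the scatter. Within the data shown here, only that one step bears directly on the change, and it was large. The remaining part of compound 3, the longer chain on the saturated ring carbon, made no difference within the scatter between compound 1 and compound 3, so it is not expected to alter the outcome.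

A large upward step is therefore expected for compound 4, of about a number 49.2 percentage points higher from compound 3 to compound 4 (beyond the scatter) in this assay. The estimated value for compound 4 is 65%, with a range from 45% to 85%.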

Compound 4, a percentage reported as inhibition, at one concentration (the size of the read-out at that concentration, not a potency): 47.2%
Beside the measured number, compound 4's estimate is 17.8 percentage points above it, within the range that was stated.
By their numbers in this assay, from the lowest: compounds 1 and 3 (each within the scatter of the next); then compound 4; then compound 2.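

The change from a 3,7-dimethylocta-2,6-dien-1-yl chain to an aryl carbamoyl group on an oxygen on an aromatic ring now has a second example in this assay, a number 31.4 percentage points higher from compound 3 to compound 4 (beyond the scatter). The earlier rise, a number 59.1 percentage points higher from compound 1 to compound 2 (beyond the scatter), came from a single pair with a (2,4-difluorophenyl)carbamoyl group and the shorter chain on the saturated ring carbon, whereas this one holds with a (4-chlorophenyl)carbamoyl group and the longer chain there, so among the compounds shown the gain does not depend on one particular halogen pattern or one chain. Nothing measured here explains why the exchange raises the read-out.

The two steps differ in both the aryl group and the chain, so these compounds cannot show which of the two parts bears on any difference in their sizes. Also open, from the compounds shown here alone, is whether the aromatic ring alone or the carbamoyl link is what counts, a question that a benzyl group on the same oxygen, with an aromatic ring but no carbamoyl part, or an unsubstituted phenylcarbamoyl group could help to answer.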